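Series notes: phenyl to carboxy on the five-membered ring

A few compounds are considered here, and "the series" means these few. Any claim that something is new, unique, unknown or untested is made for them only; others in the source may bear on it.

Of the compounds shown here, three share one core and have been measured in an assay on HEK293 cells for displacement of a labelled ligand from P2Y purinoceptor 1 (Homo sapiens), read by scintillation counting, with a stated time of 1 h; on this read-out lower numbers stand for stronger inhibition and higher numbers for weaker inhibition. Compound 1 `CC(C)(C)c1ccccc1Oc1ncccc1NC(=O)Nc1ccc(C(F)(F)F)cc1` gives 15 nM. Compound 2 `CC(C)(C)c1ccccc1Oc1ncccc1Nc1ncc(-c2ccccc2)s1` gives 15 nM. Compound 3 `CC(C)(C)c1ccccc1Oc1ncccc1Nc1nnc(-c2ccccc2)s1` gives 11 nM. All three values sit within the usual scatter of one another; compound 3 stands at the low end of that narrow spread, with compound 1 and compound 2 close beside it, so no ordering among them can be read from these numbers.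

Compound 4 `CC(C)(C)c1ccccc1Oc1ncccc1Nc1nnc(C(=O)O)s1` has not yet been measured in this assay. It differs from compound 3 by carboxy in place of phenyl on an aromatic carbon; in words, carboxy in place of phenyl on an aromatic carbon. For the measured compounds named here, no step between measured compounds covers a change of this kind, so the expectation rests only on the size of the group exchanged and on the narrow spread of the three measured values. The change is expected to move the number upward, well beyond the scatter, as a step from compound 3 to compound 4 of a 36-fold higher number from compound 3 to compound 4 (1.56 log units; beyond the scatter). Compound 4 is estimated at 400 nM, within a range from 60 nM to 3000 nM.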

Compound 4, inhibition constant: 2900 nM
Beside the measured number, compound 4's estimate is 7.3-fold (0.86 log units) below it; the range from low to high includes it.
By their numbers in this assay, from the lowest: compounds 3, 1 and 2 (each within the scatter of the next); then compound 4.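

In this assay, for the compounds shown here, the exchange of phenyl for carboxy on the aromatic carbon next to the ring sulfur brings a 260-fold higher number from compound 3 to compound 4 (2.42 log units; beyond the scatter) and is the first step to lie beyond the scatter. Going by these compounds alone, the near-level values of the earlier compounds gave no sign of this, and the result shows that the read-out depends strongly on the group at this position. Loss of the aromatic ring, the smaller group and the arrival of carboxy all come in this single step, so the step cannot be assigned to any one of them, and no measurement here bears on why the number rises.

The compounds shown leave open whether the phenyl is what counts or the carboxy is what harms: a methyl ester, a primary amide or a benzyl group on this carbon would separate the two. Also open, as far as these compounds go, is whether carboxy in place of phenyl has a step of similar size on the five-membered ring of compound 2.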